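A few compounds are considered here, and "the series" means these few. Any claim that something is new, unique, unknown or untested is made for them only; others in the source may bear on it.

Of the compounds shown here, three in this set have been measured in a functional assay on LNCaP cells (Homo sapiens) for antiproliferative activity, read by propidium iodide staining, with a stated time of 96 h (on this read-out lower numbers stand for stronger inhibition and higher numbers for weaker inhibition), and a fourth awaits its result. Compound 1 `CC(O)(CSc1cccc(C(F)(F)F)c1)C(=O)Nc1ccc(S(F)(F)(F)(F)F)cc1` gives 18300 nM. Compound 2 `CC(O)(CSc1cccc(OC(F)(F)F)c1)C(=O)Nc1ccc(S(F)(F)(F)(F)F)cc1` is its partner across one change, (trifluoromethoxy in place of trifluoromethyl on an aromatic carbon), and in this assay compound 2 gives 12800 nM. That change moved the number a 1.4-fold lower number from compound 1 to compound 2 (0.16 log units; within the scatter).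

Compound 3 `CC(O)(CSc1cccc(C(F)(F)F)c1)C(=O)Nc1cccc(S(F)(F)(F)(F)F)c1` is built from the same atoms as compound 1, joined differently; the difference between the two cores is not broken down here. In this assay compound 3 gives 12700 nM, a figure that sits alongside those of compound 1 and compound 2 without any of the three standing apart from the others.

Compound 4 `CC(O)(CSc1cccc(OC(F)(F)F)c1)C(=O)Nc1cccc(S(F)(F)(F)(F)F)c1` has not yet been measured. Among the measured compounds shown here, it is related to compound 3 by trifluoromethoxy in place of trifluoromethyl on an aromatic carbon, which is the same change as the one that carries compound 1 to compound 2. Because that earlier step was a 1.4-fold lower number from compound 1 to compound 2 (0.16 log units; within the scatter), the expectation is that the step from compound 3 to compound 4 will be of similar modest size, and the estimated change is a 1.3-fold lower number from compound 3 to compound 4 (0.10 log units; within the scatter). On that basis compound 4 is expected to give about 10000 nM in this assay, with the estimate likely to fall somewhere between 5000 nM and 20000 nM. Whether the measured value bears this out remains to be seen.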

Compound 4, half-maximal inhibitory concentration: 10900 nM
Compound 4: middle estimate off by 1.1-fold (0.04 log units), on the low side, and the stated range covers the measured number.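

In this assay, trifluoromethoxy in place of trifluoromethyl on an aromatic carbon gives a 1.2-fold lower number from compound 3 to compound 4 (0.07 log units; within the scatter), so the same change can now be read on two cores: the same change on two cores in this assay, a 1.4-fold lower number (0.16 log units; within the scatter) from compound 1 to compound 2 and a 1.2-fold lower number (0.07 log units; within the scatter) from compound 3 to compound 4, 1.2-fold (0.09 log units) apart, within the scatter of two such steps. Across these two cores, the change therefore carries over as a small step that stays within the scatter each time, and the two steps agree with each other within the scatter. This does not show that trifluoromethoxy truly improves on trifluoromethyl on either core, since neither step can be told apart from repeat-measurement noise, and two cores with such small steps cannot establish a rule for the wider series or say why the steps look as they do.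

The compounds shown leave open whether the change would still give so small a step on a core in which the pentafluorosulfanyl group gives way to a nitrile or a chlorine, or in which the sulfur of the thioether is oxidised to a sulfone. They also leave open whether a different group in the same place, such as a methoxy, a nitrile or a carboxylic acid, would give a step beyond the scatter.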